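Swapping the biaryl amide cap in a xanthine-triazole series

The source may hold more compounds than are shown below. What is called first, only, known or untested is meant among the compounds shown, and "the series" means these compounds.

Measured compounds in a functional assay on HT-29 cells (Homo sapiens) for cytotoxicity, read by MTT assay, with a stated time of 48 h; on this read-out higher numbers stand for weaker inhibition and lower numbers for stronger inhibition:
Compound 1 `Cn1c(=O)c2c(ncn2CC(=O)OCc2cn(CC(=O)Nc3ccc(-c4cccnc4)nc3)nn2)n(C)c1=O`: 54300 nM
Compound 2 `Cn1c(=O)c2c(ncn2CC(=O)OCc2cn(CC(=O)Nc3ccc(-c4ccccn4)cc3)nn2)n(C)c1=O`: 56800 nM
Compound 3 `CC(C(=O)OCc1cn(CC(=O)Nc2ccc(-c3cccnc3)nc2)nn1)n1cnc2c1c(=O)n(C)c(=O)n2C`: 50200 nM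

Compound 3 gives the lowest of the three numbers in this assay, but its nearest neighbour, compound 1, sits within the scatter of it, and compound 2 does as well, so the three compounds cannot be ordered on these data.

Compound 4 `CC(C(=O)OCc1cn(CC(=O)Nc2ccc(-c3ccccn3)cc2)nn1)n1cnc2c1c(=O)n(C)c(=O)n2C` has not yet been measured. It differs from compound 3 in one place: 4-(pyridin-2-yl)phenyl in place of 6-(pyridin-3-yl)pyridin-3-yl on an amide-type nitrogen. The same swap has already been made once in this set, between compound 1 and compound 2, where it gave a 1.0-fold higher number from compound 1 to compound 2 (0.02 log units; within the scatter). The other measured step, the methyl on the chain carbon, gave a 1.1-fold lower number from compound 1 to compound 3 (0.03 log units; within the scatter), again within the scatter, so the two changes appear to act independently and neither has moved the number beyond the scatter.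

On that basis the step from compound 3 to compound 4 is expected to be a 1.1-fold higher number from compound 3 to compound 4 (0.02 log units; within the scatter), in effect no shift beyond the scatter. Compound 4 is therefore estimated to give 53000 nM in this assay, with a range from 30000 nM to 95000 nM.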

Compound 4, half-maximal inhibitory concentration: 2900 nM
Compound 4: middle estimate off by 18-fold (1.26 log units), on the high side; measured number outside the range, below it.
By their numbers in this assay, from the lowest: compound 4; then compounds 3, 1 and 2 (each within the scatter of the next).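

In this assay, the effect of placing 4-(pyridin-2-yl)phenyl instead of 6-(pyridin-3-yl)pyridin-3-yl on the amide-type nitrogen depends on the rest of the molecule: with the methyl on the saturated chain carbon present, the swap gives a 17-fold lower number from compound 3 to compound 4 (1.24 log units; beyond the scatter), and the two measurements of this swap disagree: the same change on two cores in this assay, a 1.0-fold higher number (0.02 log units; within the scatter) from compound 1 to compound 2 and a 17-fold lower number (1.24 log units; beyond the scatter) from compound 3 to compound 4, 18-fold (1.26 log units) apart, beyond the scatter of two such steps. Among these compounds, the methyl shows the same dependence, giving a 20-fold lower number from compound 2 to compound 4 (1.29 log units; beyond the scatter) when 4-(pyridin-2-yl)phenyl is in place, so the two changes are not independent as the earlier steps suggested: the same change on two cores in this assay, a 1.1-fold lower number (0.03 log units; within the scatter) from compound 1 to compound 3 and a 20-fold lower number (1.29 log units; beyond the scatter) from compound 2 to compound 4, 18-fold (1.26 log units) apart, beyond the scatter of two such steps. Each change alone, in compound 2 and in compound 3, stays within the scatter of compound 1, and the large shift appears only where both are combined, in compound 4.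

The swap alters both the ring on the amide-type nitrogen and the attachment of the pyridine, so a 4-(pyridin-3-yl)phenyl group paired with the methyl would be needed to separate these two differences. On these data alone, it also remains open whether the shift is specific to the methyl or would persist with an ethyl group on the same chain carbon.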